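Replacing Hydroxy with 4-Aminophenyl in Compound 2

A few compounds are considered here, and "the series" means these few. Any claim that something is new, unique, unknown or untested is made for them only; others in the source may bear on it.

Measured in a functional assay on KB cells (Homo sapiens) for antiproliferative activity, read by sulforhodamine B assay, with a stated time of 48 h; a lower number here means a stronger inhibitor of growth, a higher number a weaker inhibitor of growth:
- compound 1 `COc1ccc(S(=O)(=O)Nc2cccc(CCc3ccc(C(=O)Nc4ccccc4N)cc3)c2)cc1`: 678 nM
- compound 2 `COc1ccc(S(=O)(=O)Nc2ccccc2CCc2ccc(C(=O)NO)cc2)cc1`: > 10000 nM (a limit, not a number)
- compound 3 `Nc1ccccc1NC(=O)c1ccc(CCc2ccccc2NS(=O)(=O)c2ccc(Br)cc2)cc1`: 124 nM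

Compound 2 stands at the limit of > 10000 nM in this assay, at which 1 of the 3 values shown sits. Compound 4 `COc1ccc(S(=O)(=O)Nc2ccccc2CCc2ccc(C(=O)Nc3ccc(N)cc3)cc2)cc1` carries 4-aminophenyl in place of hydroxy on an amide-type nitrogen. Compound 1 at 678 nM and compound 3 at 124 nM also carry an aminophenyl amide, but with a different substitution pattern, so they offer only limited guidance. A small step towards stronger growth inhibition is expected, with an at least 1.1-fold lower number from compound 2 to compound 4 (0.04 log units; that floor lies within the scatter) as the estimate in this assay. Compound 4 is estimated at 9000 nM, with an expected range of 2500 nM to 30000 nM.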

Compound 4, concentration for 50% growth inhibition: 286 nM
The estimate for compound 4 lay 31-fold (1.50 log units) above the measured number; the whole stated range lies above it.
By their numbers in this assay, from the lowest: compound 3; then compound 4; then compound 1. At a limit, above all of these: compound 2.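

In this assay, going by these compounds alone, putting 4-aminophenyl in place of hydroxy on the amide-type nitrogen gives an at least 34-fold lower number from compound 2 to compound 4 (1.54 log units; beyond the scatter), the first single change at this position that can be read. Compound 2 holds a limit, not a number: the limit of > 10000 nM in this assay, at which 1 of the 4 values shown sits. The size of the step is therefore bounded on one side only, and compounds 1 and 3 differ from compound 4 in more than one place, so they could not show this.

As far as these compounds go, it remains open whether a plain phenyl or a methyl group on this nitrogen would give a similar step on the core of compound 4.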